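The source may report more compounds than this note shows. Statements on the series, on what has been measured and on what is new or still open speak of the compounds shown alone.

Compound 2 `COc1ccc(C2CC(c3ccc(S(C)(=O)=O)cc3)=NN2c2ccc(S(N)(=O)=O)cc2)cc1` stands lowest of the two numbers in a functional assay on the whole organism for inhibition, with Rattus norvegicus as the target, read by paw edema, with a stated time of 3 h, at a dose of 50 mg/kg by the oral route (on this read-out lower numbers stand for less inhibition and higher numbers for more inhibition at the one dose given (going by the name of the read-out)), where compound 2 gives 42.4%, while compound 1 `CS(=O)(=O)c1ccc(C2=NN(c3ccc(S(N)(=O)=O)cc3)C(c3ccc(F)cc3)C2)cc1` gives 65.7%. Among the measured compounds shown here, the only measured step, a number 23.3 percentage points lower from compound 1 to compound 2 (beyond the scatter), concerns methoxy in place of fluoro on an aromatic carbon and so does not address the change at hand. Compound 3 `COc1ccc(C2CC(c3ccc(S(C)(=O)=O)cc3)=NN2c2ccc(S(N)(=O)=O)cc2)cc1OC` differs from compound 2 by methoxy in place of hydrogen on an aromatic carbon. For the measured compounds named here, with no step bearing directly on methoxy in place of hydrogen on an aromatic carbon, and the one measured step only modest, the expected change is small and within the scatter, as a number 4.4 percentage points lower from compound 2 to compound 3 (within the scatter). Compound 3 is therefore estimated at 38%, between 20% and 55%.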

Compound 3, a percentage reported as inhibition, in the whole organism at one dose (the size of the read-out at that dose, not a potency): 45.5%
Beside the measured number, compound 3's estimate is 7.5 percentage points below it; low and high end bracket the measured number.
By their numbers in this assay, from the lowest: compounds 2 and 3 (each within the scatter of the next); then compound 1.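

In this assay a methoxy ortho to a methoxy group, turning 4-methoxyphenyl into 3,4-dimethoxyphenyl, brings a number 3.1 percentage points higher from compound 2 to compound 3 (within the scatter) and so this aromatic carbon takes the added group with no change beyond the scatter. Set against 4-fluorophenyl, the 3,4-dimethoxyphenyl group brings a number 20.2 percentage points lower from compound 1 to compound 3 (beyond the scatter) and so the added methoxy leaves the gap to compound 1 open. Nothing measured here speaks to the reason for these numbers. As far as these compounds go, whether a hydroxyl or an amine on this same carbon would behave like methoxy stays open.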